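Three flat values, then a ring swapped out

The source may hold more compounds than are shown below. What is called first, only, known or untested is meant among the compounds shown, and "the series" means these compounds.

compound 1 `CCN1CCN(c2cc(C(F)(F)F)nc(SCc3ccc(C(F)(F)F)cc3)n2)CC1` gives 25600 nM
compound 2 `CC(C)(C)OC(=O)N1CCN(c2cc(C(F)(F)F)nc(SCc3ccc(C(F)(F)F)cc3)n2)CC1` gives 22200 nM
compound 3 `FC(F)(F)c1ccc(CSc2nc(N3CCN(c4ccccn4)CC3)cc(C(F)(F)F)n2)cc1` gives 23500 nM

In a functional assay on MGC-803 cells (Homo sapiens) for inhibition, read by MTT assay, with a stated time of 72 h (on this read-out higher numbers stand for weaker inhibition and lower numbers for stronger inhibition), compound 1 stands level with the other two, since a 1.2-fold lower number from compound 1 to compound 2 (0.06 log units; within the scatter) and a 1.1-fold lower number from compound 1 to compound 3 (0.04 log units; within the scatter) both lie within the scatter. Compound 4 `FC(F)(F)c1ccc(CSc2nc(Sc3nncs3)cc(C(F)(F)F)n2)cc1` has not been measured yet. Its change is larger: (1,3,4-thiadiazol-2-yl)sulfanyl in place of 4-ethylpiperazin-1-yl on an aromatic carbon with (1,3,4-thiadiazol-2-yl)sulfanyl in place of 4-ethylpiperazin-1-yl on an aromatic carbon. The two steps above only swap the group on the amine nitrogen and keep the ring, so they guide this change loosely. Among the compounds with values here, no measured compound shows the ring replaced. No step beyond the scatter is expected in this assay and the expected step is a 1.3-fold lower number from compound 1 to compound 4 (0.11 log units; within the scatter) with its direction uncertain. For compound 4 the estimate is 20000 nM with an expected range from 7000 nM to 50000 nM here.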

Compound 4, half-maximal inhibitory concentration: 10900 nM
Compound 4: the middle estimate sits 1.8-fold (0.26 log units) above what was measured; the range from low to high includes it.
By their numbers in this assay, from the lowest: compound 4; then compounds 2, 3 and 1 (each within the scatter of the next).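

Within the data shown here, putting (1,3,4-thiadiazol-2-yl)sulfanyl in place of 4-ethylpiperazin-1-yl gives, in this assay, a 2.3-fold lower number from compound 1 to compound 4 (0.37 log units; beyond the scatter), the only step here beyond the scatter, though a modest one. At this position, replacing the whole ring group moves the number, while changing only the group on the ring's amine nitrogen, as in compound 2 and compound 3, did not. No measured evidence here explains this step.

The ring and the sulfur link change together, and the compounds shown do not separate them. On these data alone, whether a 1,3,4-thiadiazol-2-yl ring joined through an amine nitrogen, or a plain phenylsulfanyl group, would match compound 4 stays open.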